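This account rests on a few compounds, and the source may have more. Where it says the series, first, only, none or still open, it means among the compounds named here.

Measured so far:
Compound 1, `CCOC(=O)COCn1cc(/C=C/Br)c(=O)[nH]c1=O`: > 200000 nM
Compound 2, `O=c1[nH]c(=O)n(COCCO)cc1/C=C/Br`: > 200000 nM

In an ADME assay on L1210/0 cells (Mus musculus) for cytotoxicity, with a stated time of 48 h (a lower number here means a stronger inhibitor, a higher number a weaker inhibitor), compound 1 reaches only a limit of the assay, > 200000 nM, not a number. In this assay compound 2 likewise gives only a limit, > 200000 nM, so no true number exists for it either. Compound 2 thus stands at the limit, and every value shown sits there too: the limit of > 200000 nM in this assay, at which 2 of the 2 values shown sit. Among the measured compounds shown here, the one measured step, a step that the two limits leave unreadable from compound 1 to compound 2, cannot be read in size because both of its ends are limits.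

The unmeasured compound 3, `O=c1ccn(COCCO)c(=O)[nH]1`, differs from compound 2 on the shared core: hydrogen in place of 2-bromoethenyl on an aromatic carbon. For the measured compounds named here, no measured step touches the 2-bromoethenyl group, so the data give no guide to how large a step to expect in this assay or in which direction; the only guidance is that both values so far lie at the limit. Compound 3 is therefore expected to remain at or beyond the limit, with an estimated step that the limit leaves unreadable from compound 2 to compound 3 that cannot be taken as reliable. Compound 3 is estimated at 300000 nM, in a range from 100000 nM to 1000000 nM.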

Compound 3, half-maximal inhibitory concentration: > 200000 nM
Compound 3 ended at the assay's limit; the forecaster's own chance of this, stated with the estimate: 85%; the middle value does not contradict the limit.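

No step can be read between compound 2 and compound 3, because both end at a limit of the assay, not at a number: the limit of > 200000 nM in this assay, at which 3 of the 3 values shown sit.

The compounds shown leave open whether any change to the shared core or its chain would give a true number in this assay, and how much each group contributes.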